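Replacing Imidazolyl with Triazolyl: What Paw Edema May Show

A few compounds are considered here, and "the series" means these few. Any claim that something is new, unique, unknown or untested is made for them only; others in the source may bear on it.

Of the compounds shown here, three have been measured in a functional assay on the whole organism for inhibition, with Rattus norvegicus as the target, read by paw edema; a higher number here means that more compound is needed for the effect, a lower number that less compound is needed.
Compound 1 `O=C(O)c1cc(-c2csnn2)ccc1O`: in this assay compound 1 reaches only a limit, > 200 mg/kg.
Compound 2 `O=C(O)c1cc(-n2ccnc2)ccc1O`: in this assay compound 2 gives 75 mg/kg.
Compound 3 `O=C(O)c1ccc(-c2nccs2)cc1O`: in this assay compound 3 gives 110 mg/kg.

Among the two numbers, compound 2 has the lower one, but compound 3 sits within the scatter of it, so the two cannot be ranked. Compound 1 is known only as a limit (the limit of > 200 mg/kg in this assay, at which 1 of the 3 values shown sits). Among the measured compounds shown here, the single measured step that touches compound 2 is an at least 2.6-fold lower number from compound 1 to compound 2 (0.42 log units; beyond the scatter), where one five-membered ring gives way to another at the same place and the number falls at least modestly.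

Compound 4 `O=C(O)c1cc(-n2cncn2)ccc1O` differs from compound 2 as follows: 1H-1,2,4-triazol-1-yl in place of 1H-imidazol-1-yl on an aromatic carbon. For the measured compounds named here, no measured step exchanges one nitrogen-linked five-membered ring for a closely related one, so the step of an at least 2.6-fold lower number from compound 1 to compound 2 (0.42 log units; beyond the scatter) bears on the present change only loosely, as a sign that rings of this kind at this place can be exchanged without losing the effect altogether. A step within the scatter is therefore expected, with a slightly higher number judged somewhat more likely than a lower one. Compound 4 is expected to give about 100 mg/kg, between 50 mg/kg and 250 mg/kg. That estimate corresponds to an expected step of a 1.3-fold higher number from compound 2 to compound 4 (0.12 log units; within the scatter).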

Compound 4, dose for half-maximal effect: 200 mg/kg
For compound 4 the middle estimate is 2.0-fold (0.30 log units) below the measured one; low and high end bracket the measured number.
By their numbers in this assay, from the lowest: compounds 2, 3 and 4 (each within the scatter of the next, the first and the last beyond it).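

In this assay, 1H-1,2,4-triazol-1-yl in place of 1H-imidazol-1-yl, on an aromatic carbon meta to a carboxy group and para to a hydroxy group, gives a 2.7-fold higher number from compound 2 to compound 4 (0.43 log units; beyond the scatter), a modest step. The two rings have the same 5 heavy atoms, and the entering ring has 3 hetero atoms and 3 hydrogen-bond acceptors against 2 of each in the leaving ring, so a difference of this size in the ring's make-up is enough to move the number beyond the scatter, which the earlier exchange of 1,2,3-thiadiazol-4-yl for 1H-imidazol-1-yl could not show. Compound 1 is known only as a limit: the limit of > 200 mg/kg in this assay, at which 1 of the 4 values shown sits.
The remaining step, a number no higher from compound 1 to compound 4 (the limit leaves the size open), cannot be read.

A single step cannot say why the number rises, and no property of these rings is measured here that would explain it. Also open, as far as these compounds go, is how the effect would respond at this place to groups of another kind, such as an amine, a carboxylic acid or a longer chain.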